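Replacing the 5-bromopyridin-3-yl group of compound 1

This account rests on a few compounds, and the source may have more. Where it says the series, first, only, none or still open, it means among the compounds named here.

Measured in an ADME assay on CHO cells (Cricetulus griseus) for cytotoxicity, read by MTT assay; on this read-out higher numbers stand for weaker inhibition and lower numbers for stronger inhibition:
compound 1 `O=C(Nc1ccc(-c2nc3ccccc3[nH]2)cc1)c1cncc(Br)c1` gives 189000 nM
compound 2 `O=C(Nc1ccc(-c2nc3ccccc3[nH]2)cc1)c1cncc(C(F)(F)F)c1` gives 35000 nM

Compound 1 stands highest of the two in this assay and compound 2 lies nearest to it. In compound 3 `O=C(Nc1ccc(-c2nc3ccccc3[nH]2)cc1)c1cc(Cl)nc(Cl)c1` the shared core stays, with one change (2,6-dichloropyridin-4-yl in place of 5-bromopyridin-3-yl on a carbonyl carbon). Among the measured compounds shown here, the one measured step that also removes the bromo group is modest (a 5.4-fold lower number from compound 1 to compound 2 (0.73 log units; beyond the scatter)). It bears on this change only in part, but compound 1 at 189000 nM has little company so high, so a lower number is expected. The expected step is of similar or smaller size (a 2.4-fold lower number from compound 1 to compound 3 (0.37 log units; beyond the scatter)). Compound 3 is estimated at 80000 nM (expected range 25000 nM to 220000 nM).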

Compound 3, half-maximal inhibitory concentration: 184000 nM
Compound 3: middle estimate off by 2.3-fold (0.36 log units), on the low side; low and high end bracket the measured number.
By their numbers in this assay, from the lowest: compound 2; then compounds 3 and 1 (each within the scatter of the next).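

In this assay, putting 2,6-dichloropyridin-4-yl in place of 5-bromopyridin-3-yl on the carbonyl carbon gives a 1.0-fold lower number from compound 1 to compound 3 (0.01 log units; within the scatter), so these two groups cannot be told apart on this read-out. Losing the bromo group therefore does not by itself bring the lower number seen in the other step, a 5.4-fold lower number from compound 1 to compound 2 (0.73 log units; beyond the scatter), although that pair keeps the ring and changes only the substituent. Nothing measured here accounts for this result.

As far as these compounds go, it remains open how an amine or a carboxylic acid would read in place of these groups on the carbonyl carbon.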